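A few compounds are considered here, and "the series" means these few. Any claim that something is new, unique, unknown or untested is made for them only; others in the source may bear on it.

Compound 2 `COc1ccc(-c2cc(-c3ccc(C(N)=O)cc3)cnc2N)cn1` carries a carbamoyl group on its shared core. For the measured compounds named here, in a physicochemical assay for lipophilicity, at pH 7.4 (on this read-out lower numbers stand for lower lipophilicity and higher numbers for higher lipophilicity), compound 2 gives 1.7, the highest of the two numbers measured so far. Going by the values given here, the only other measured compound, compound 1 `COc1ccc(-c2cc(-c3ccc(C(=O)O)cc3)cnc2N)cn1`, gives 0.8 in this assay; the step of a number 0.90 log units higher from compound 1 to compound 2 (beyond the scatter) lies beyond the scatter. Compound 3 `CNC(=O)c1ccc(-c2cnc(N)c(-c3ccc(OC)nc3)c2)cc1` has not yet been measured. Its change from compound 2 is methyl in place of hydrogen on an amide-type nitrogen. Among the compounds with values here, no measured step matches this change: the single step so far, a number 0.90 log units higher from compound 1 to compound 2 (beyond the scatter), replaces a hydroxy by an amino on a carbonyl carbon, a different kind of edit at the same end of the molecule, so it bears on compound 3 only loosely. For compound 3 a small rise in this assay is expected, with the step of a number 0.40 log units higher from compound 2 to compound 3 (beyond the scatter). The estimate for compound 3 in this assay is 2.1, between 1.7 and 2.5.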

Compound 3, distribution coefficient: 1.8
For compound 3 the middle estimate is 0.30 log units above the measured one; low and high end bracket the measured number.
By their numbers in this assay, from the lowest: compound 1; then compounds 2 and 3 (each within the scatter of the next).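

Methyl in place of hydrogen on the amide-type nitrogen gives a number 0.10 log units higher from compound 2 to compound 3 (within the scatter) in this assay and so, on this read-out, adding this one carbon leaves compound 2 and compound 3 indistinguishable. Methylamino in place of hydroxy on the carbonyl carbon gives a number 1.00 log units higher from compound 1 to compound 3 (beyond the scatter) and this shows that the clear separation from compound 1 seen with the amino group of compound 2 also holds with the methylamino group. Nothing in the data shown offers a reason for this result.

Going by these compounds, it remains open whether this nitrogen would tolerate something larger just as quietly, such as an ethyl group, a longer chain or a second methyl. On these data alone, it is equally open how a cyclic amine such as piperidine, attached to the carbonyl carbon through its nitrogen, would read in this assay.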